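The source may report more compounds than this note shows. Statements on the series, on what has been measured and on what is new or still open speak of the compounds shown alone.

Measured compounds:
compound 1 `O=C(/C=C/c1ccc2c(c1)B(O)OC2)c1cccnc1` — 18500 nM
compound 2 `Nc1ccc(C(=O)/C=C/c2ccc3c(c2)B(O)OC3)cc1` — 20200 nM

Working notes on the series. Both measured compounds share the same core and differ only in the ring on the carbonyl carbon. In a functional assay on SK-OV-3 cells (Homo sapiens) for cytotoxicity, read by MTT assay, with a stated time of 48 h (on this read-out higher numbers stand for weaker inhibition and lower numbers for stronger inhibition), compound 1 gives 18500 nM, and compound 2 gives 20200 nM. The single measured step, a 1.1-fold higher number from compound 1 to compound 2 (0.04 log units; within the scatter), lies within the scatter, so on the numbers shown compound 2 stands level with compound 1; it carries the higher of the two numbers, but the gap carries no weight.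

Compound 3 `O=C(/C=C/c1ccc2c(c1)B(O)OC2)c1ccccc1F` is not yet measured. It differs from compound 2 by 2-fluorophenyl in place of 4-aminophenyl on a carbonyl carbon. Among the compounds with values here, no measured step covers an exchange of this kind; the only step in hand, from compound 1 to compound 2, also swaps the ring on the carbonyl carbon and stays within the scatter. On that basis the expected change in this assay for compound 3 is none beyond the scatter, in either direction, and the estimate for compound 3 is 19000 nM, with a range of 7000 nM to 50000 nM. The step this implies, a 1.1-fold lower number from compound 2 to compound 3 (0.03 log units; within the scatter), is expected to stay within the scatter.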

Compound 3, half-maximal inhibitory concentration: 3700 nM
Beside the measured number, compound 3's estimate is 5.1-fold (0.71 log units) above it; measured number below the stated range.
By their numbers in this assay, from the lowest: compound 3; then compounds 1 and 2 (each within the scatter of the next).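

In this assay the ring on the carbonyl carbon proves not to be indifferent: a 5.5-fold lower number from compound 2 to compound 3 (0.74 log units; beyond the scatter) and a 5.0-fold lower number from compound 1 to compound 3 (0.70 log units; beyond the scatter) both lie beyond the scatter, while the earlier exchange of pyridin-3-yl for 4-aminophenyl at the same place did not move the number beyond it. Compound 3, with 2-fluorophenyl, therefore stands apart from both earlier compounds with the lowest number of the three, although the steps are modest in size and the values remain those of a weak cytotoxic read-out for all of the series shown. Nothing in hand explains why this ring exchange lowers the number while the earlier one did not.

The three compounds leave open whether the lower number goes with the fluorine atom or with where it sits on the ring, a question that plain phenyl, 4-fluorophenyl or 2-chlorophenyl on the same carbonyl carbon would address. Also open, as far as these compounds go, is whether the separation of compound 3 from the others in this assay extends to other cell lines.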